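A few compounds are considered here, and "the series" means these few. Any claim that something is new, unique, unknown or untested is made for them only; others in the source may bear on it.

Series of ureas on a shared core that varies only in the aromatic group attached to the sulfur at the end of the chain. Among the measured compounds shown here, compound 3 `CCCCCCN(CCCCCSc1nc2cc(C)ccc2[nH]1)C(=O)Nc1ccc(F)cc1F` gives 2060 nM in an assay on cells (Macrophage) for inhibition of sterol O-acyltransferase 1 (Mus musculus); a lower number here means a stronger inhibitor, a higher number a weaker inhibitor; on the three numbers known it has the lowest number, but its nearest neighbour compound 2 `CCCCCCN(CCCCCSc1nc2ccccc2s1)C(=O)Nc1ccc(F)cc1F` gives 2730 nM and compound 1 `CCCCCCN(CCCCCSc1nc2ccccc2o1)C(=O)Nc1ccc(F)cc1F` gives 3500 nM in this assay, and the gaps to both stay within the scatter.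

Compound 4 `CCCCCCN(CCCCCSc1nc2ccc[nH]c-2n1)C(=O)Nc1ccc(F)cc1F` is not yet measured. Relative to compound 3 the change is a group of 9 heavy atoms (6 carbon, 3 nitrogen; one five-membered aromatic ring with 2 hetero atoms, one six-membered aromatic ring with 1 hetero atom) in place of a group of 10 heavy atoms (8 carbon, 2 nitrogen; one five-membered aromatic ring with 2 hetero atoms, one six-membered aromatic ring of carbon only), on a sulfur. The measured steps that bear on this are the swaps of the same kind at the same place: a 1.3-fold lower number from compound 1 to compound 2 (0.11 log units; within the scatter), a 1.7-fold lower number from compound 1 to compound 3 (0.23 log units; within the scatter) and a 1.3-fold lower number from compound 2 to compound 3 (0.12 log units; within the scatter). Every one of these exchanges of a bicyclic heteroaromatic group on the sulfur left the number where it was, within the scatter, so no case has yet shown that this part of the molecule moves the number beyond it.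

The expectation for compound 4 in this assay is therefore a step of a 1.2-fold higher number from compound 3 to compound 4 (0.08 log units; within the scatter), i.e. no change beyond the scatter, with a slight lean toward a higher number on no firmer ground than that compound 3 sits at the low end of the three. Compound 4 is estimated at 2500 nM, with a range from 1200 nM to 5500 nM.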

Compound 4, half-maximal inhibitory concentration: 5470 nM
Compound 4: the middle estimate sits 2.2-fold (0.34 log units) below what was measured; the range from low to high includes it.
By their numbers in this assay, from the lowest: compounds 3, 2, 1 and 4 (each within the scatter of the next, the first and the last beyond it).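

In this assay, the exchange on the sulfur gives its first step beyond the scatter (a 2.7-fold higher number from compound 3 to compound 4 (0.42 log units; beyond the scatter)), so this position is no longer shown to be indifferent to the group it carries, although the step is modest and the swap removes the methyl and puts a nitrogen into the six-membered aromatic ring at once. The same entering group stays within the scatter of the other two groups (a 2.0-fold higher number from compound 2 to compound 4 (0.30 log units; within the scatter)) and (a 1.6-fold higher number from compound 1 to compound 4 (0.19 log units; within the scatter)), so only the gap to compound 3 stands out and the four compounds do not separate into two clear levels. No measurement on hand accounts for the step.

The compounds shown leave open how the step divides between the methyl and the ring nitrogen, a question that an unsubstituted 1H-benzimidazol-2-yl on the same chain would help to settle. Also open, from the compounds shown here alone, is whether the position tolerates anything other than a fused bicyclic group, such as a single phenyl ring or a carboxylic acid at the end of the chain on the sulfur.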